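The source may hold more compounds than are shown below. What is called first, only, known or untested is meant among the compounds shown, and "the series" means these compounds.

Of the compounds shown here, three have so far been measured in a functional assay on cells (Erythrocyte, Homo sapiens); on this read-out higher numbers stand for weaker inhibition and lower numbers for stronger inhibition. Compound 1 `COc1cc(CS(=O)(=O)c2nc3ccccc3[nH]2)ccc1OCc1nccc(OCC(F)(F)F)c1C` gives 1310 nM, compound 2 `COCCCOc1ccnc(COc2ccc(CS(=O)(=O)c3nc4cc(OC(F)F)ccc4[nH]3)cc2OC)c1C` gives 142 nM, and compound 3 `COCCCOc1ccnc(COc2ccc(CS(=O)(=O)c3nc4cc(OC)ccc4[nH]3)cc2OC)c1C` gives 817 nM. Compound 3 thus holds the second highest of the three numbers. Its nearest neighbour is compound 1, whose number sits within the scatter of it. Going by the values given here, compound 2 lies clearly lower, and the only step measured between two compounds that differ in a single place is a 5.8-fold higher number from compound 2 to compound 3 (0.76 log units; beyond the scatter).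

Compound 4 `COc1ccc2[nH]c(S(=O)(=O)Cc3ccc(OCc4nccc(OCC(F)(F)F)c4C)c(OC)c3)nc2c1` has not been measured. It differs from compound 3 in one place: trifluoromethyl in place of 2-methoxyethyl on a saturated chain carbon bound to an oxygen on an aromatic ring. Among the compounds with values here, no measured step covers this exact swap of chains. The step of a 5.8-fold higher number from compound 2 to compound 3 (0.76 log units; beyond the scatter) concerns a different part of the molecule and offers no direct guide here. Compound 1 also carries 2,2,2-trifluoroethoxy but differs from compound 4 elsewhere, so only its value can be compared; that value and the value of compound 3 lie within the scatter of each other, which suggests that this chain change on its own moves the number little. The expected step is therefore a 1.2-fold higher number from compound 3 to compound 4 (0.09 log units; within the scatter), within the scatter. For compound 4 the estimate in this assay is 1000 nM, with a range from 400 nM to 2500 nM.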

Compound 4, half-maximal inhibitory concentration: 1760 nM
For compound 4 the middle estimate is 1.8-fold (0.25 log units) below the measured one; measured number inside the range.
By their numbers in this assay, from the lowest: compound 2; then compounds 3, 1 and 4 (each within the scatter of the next, the first and the last beyond it).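

Going by these compounds alone, this is the first measured change at this place on the molecule. In this assay, exchanging 3-methoxypropoxy for 2,2,2-trifluoroethoxy gives a modest loss of inhibition that lies just beyond the scatter (a 2.2-fold higher number from compound 3 to compound 4 (0.33 log units; beyond the scatter)), so this chain has some influence on the number, though not a large one. The same result also gives a second single change, methoxy in place of hydrogen on an aromatic carbon, and with 2,2,2-trifluoroethoxy held fixed this change leaves the two compounds within the scatter of each other (a 1.3-fold higher number from compound 1 to compound 4 (0.13 log units; within the scatter)), so on these numbers the added methoxy makes no clear difference.

The compounds shown leave open how a plain butyl chain, or a chain ending in an amine or a carboxylic acid, would read on this oxygen, and whether the chain swap gives a similar step when difluoromethoxy sits on the shared core in place of methoxy. Nothing available here speaks to why the number moves with this chain.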